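This account rests on a few compounds, and the source may have more. Where it says the series, first, only, none or still open, it means among the compounds named here.

Compound 1 `Cc1cccc(Cc2cnc(CCc3ccc(-c4ccccc4C(=O)O)cc3)[nH]2)c1`: 4310 nM
Compound 2 `N#Cc1ccccc1Cc1cnc(CCc2ccc(-c3ccccc3C(=O)O)cc2)[nH]1`: 5480 nM
Compound 3 `COc1ccc(Cc2cnc(CCc3ccc(-c4ccccc4C(=O)O)cc3)[nH]2)cc1`: 5360 nM

In an in vitro functional assay on cells for agonist activity at Bombesin receptor subtype-3 (Homo sapiens), read by luminescence and calcium flux (a lower number here means that less compound is needed, a higher number that more compound is needed for the effect), compound 1 has the lowest of the three numbers, but a 1.3-fold higher number from compound 1 to compound 2 (0.10 log units; within the scatter) and a 1.2-fold higher number from compound 1 to compound 3 (0.09 log units; within the scatter) both fall within the scatter, so the three measured compounds cannot be separated. Compound 4 `CCC(C)(CC)Cc1cnc(CCc2ccc(-c3ccccc3C(=O)O)cc2)[nH]1` is not yet measured; it differs from compound 1 in one place: 1-ethyl-1-methylpropyl in place of 3-methylphenyl on a saturated chain carbon bound to an aromatic carbon. Every measured step exchanged one aromatic ring for another at this position, and each stayed within the scatter, as a 1.0-fold lower number from compound 2 to compound 3 (0.01 log units; within the scatter) also shows. For the measured compounds named here, no measured step replaces the ring with a chain, so none bears directly on this change. Compound 4 is therefore expected to land near compound 1, with a wide range: 5000 nM, from 1500 nM to 17000 nM. The expected step is a 1.2-fold higher number from compound 1 to compound 4 (0.06 log units; within the scatter).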

Compound 4, half-maximal effective concentration: 76 nM
Compound 4: middle estimate off by 66-fold (1.82 log units), on the high side; the measured number lies below the stated range.
By their numbers in this assay, from the lowest: compound 4; then compounds 1, 3 and 2 (each within the scatter of the next).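

Swapping one aromatic ring for another at this position left the numbers within the scatter, but replacing the ring with 1-ethyl-1-methylpropyl gives a 57-fold lower number from compound 1 to compound 4 (1.75 log units; beyond the scatter) and a 71-fold lower number from compound 3 to compound 4 (1.85 log units; beyond the scatter) and also a 72-fold lower number from compound 2 to compound 4 (1.86 log units; beyond the scatter) in this series. The position therefore responds strongly to the kind of group placed there, even though it did not separate the three ring compounds. Nothing measured here gives a reason for this drop.

As far as these compounds go, it remains open whether the branching or the loss of the aromatic ring matters more. A straight pentyl chain or a cyclohexyl ring at this place would help separate the two.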